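The source may report more compounds than this note shows. Statements on the series, on what has been measured and on what is new or still open speak of the compounds shown alone.

Measured compounds and their values:

Compound 1, `CC(C)(C)c1cc(NC(=O)[C@@H]2CCCCN2C2CC2)no1`: 0.183 h
Compound 2, `CC(C)(C)c1cc(NC(=O)[C@@H]2CCCCN2C2CCOCC2)no1`: 0.317 h
Compound 3, `CC(C)(C)c1cc(NC(=O)[C@@H]2CCCCN2C(=O)C2CCCCC2)no1`: 0.483 h

In an ADME assay (liver) for metabolic stability, with Liver microsome (Homo sapiens) as the target, read by LC-MS, using microsomes and NADPH, tested at 1 uM (on this read-out higher numbers stand for a longer-lived compound and lower numbers for a shorter-lived compound), compound 2 holds the middle place of the three numbers. Its nearest neighbour is compound 3, separated by a 1.5-fold higher number from compound 2 to compound 3 (0.18 log units; within the scatter), and its furthest is compound 1, separated by a 1.7-fold higher number from compound 1 to compound 2 (0.24 log units; within the scatter). Within the data shown here, neither gap is beyond the scatter, so the three compounds cannot be set in any firm order on these numbers alone; only the step of a 2.6-fold higher number from compound 1 to compound 3 (0.42 log units; beyond the scatter) is large enough to count as a real difference.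

Compound 4, `CC(C)(C)c1cc(NC(=O)[C@@H]2CCCCN2C(=O)N2CCSCC2)no1`, has not yet been measured. It differs from compound 2 by (thiomorpholin-4-yl)carbonyl in place of oxan-4-yl on an amine nitrogen in a ring.

Among the measured compounds shown here, two measured steps bear on this change. The step of a 1.5-fold higher number from compound 2 to compound 3 (0.18 log units; within the scatter) also swaps the oxan-4-yl for a carbonyl-linked group and stays within the scatter. The step of a 2.6-fold higher number from compound 1 to compound 3 (0.42 log units; beyond the scatter) brings in the same kind of carbonyl-linked group and is modest but beyond the scatter. Taken together, these suggest that a carbonyl-linked substituent in this place leaves the half-life similar or a little longer, so the step to compound 4 is expected to be small and upward, a 1.4-fold higher number from compound 2 to compound 4 (0.15 log units; within the scatter), and may well fall within the scatter.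

The half-life of compound 4 is therefore estimated at 0.45 h, with a likely range from 0.22 h to 0.95 h.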

Compound 4, half-life: < 0.0834 h
Compound 4: a limit, no number; the forecaster's own chance of this, stated with the estimate: 5%; middle value at least 5.3-fold (0.73 log units) from the limit.
By their numbers in this assay, from the lowest: compounds 1, 2 and 3 (each within the scatter of the next, the first and the last beyond it). At a limit, below all of these: compound 4.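

In this assay compound 4 gives a limit and not a number: the limit of < 0.0834 h in this assay, at which 1 of the 4 values shown sits. The earlier compounds shown here left it possible that a carbonyl on the amine nitrogen in a ring would keep the half-life in the range already seen, but the group on that carbonyl turns out to decide the read-out, since thiomorpholin-4-yl in place of cyclohexyl on a carbonyl carbon gives an at least 5.7-fold lower number from compound 3 to compound 4 (0.76 log units; beyond the scatter). The change also takes the value past those of the compounds with no carbonyl at this place, with an at least 3.8-fold lower number from compound 2 to compound 4 (0.57 log units; beyond the scatter) and an at least 2.1-fold lower number from compound 1 to compound 4 (0.34 log units; beyond the scatter), so among the four compounds a carbonyl-linked group is found at both ends of the order, compound 3 going against any rule that such a link shortens the half-life and compound 4 against any rule that it lengthens it.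

As far as these compounds go, what remains open is which part of the entering group goes with the shorter half-life, the ring sulfur or the ring nitrogen bound to the carbonyl, and morpholin-4-yl or piperidin-1-yl on the same carbonyl would separate the two. The limit also leaves open how far compound 4 really lies from the other three.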